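The source may report more compounds than this note shows. Statements on the series, on what has been measured and on what is new or still open speak of the compounds shown alone.

Three compounds share one core and differ only in the group on the amide-type nitrogen. Compound 1 `O=C(Nc1ccccc1)c1cccc(/C=C2\CC(=O)N(c3ccccc3)C2=O)c1` carries a plain phenyl there; in an ADME assay on SW480 cells (Homo sapiens) for cytotoxicity, read by MTT assay, with a stated time of 72 h (on this read-out lower numbers stand for stronger inhibition and higher numbers for weaker inhibition), compound 1 gives > 100000 nM, which is a limit of the assay rather than a number. Compound 2 `Cc1ccc(NC(=O)c2cccc(/C=C3\CC(=O)N(c4ccccc4)C3=O)c2)cc1C` carries a 3,4-dimethylphenyl, and in this assay compound 2 gives > 100000 nM, again a limit. Compound 3 `O=C(Nc1ccc(OC(F)F)cc1)c1cccc(/C=C2\CC(=O)N(c3ccccc3)C2=O)c1` carries a 4-(difluoromethoxy)phenyl, and in this assay compound 3 gives > 100000 nM, also a limit. Among the measured compounds shown here, compound 3 therefore stands where every compound measured so far stands: at the limit of > 100000 nM in this assay, at which 3 of the 3 values shown sit. The step that the two limits leave unreadable from compound 1 to compound 2 cannot be read, nor can a step that the two limits leave unreadable from compound 1 to compound 3 or a step that the two limits leave unreadable from compound 2 to compound 3, since each end sits at the same limit.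

Compound 4 `O=C(NCc1ccccc1)c1cccc(/C=C2\CC(=O)N(c3ccccc3)C2=O)c1` continues from compound 3 with the change (benzyl in place of 4-(difluoromethoxy)phenyl on an amide-type nitrogen). For the measured compounds named here, none of the measured steps gives a readable size, so no direction can be taken from them; what the three measured compounds show is only that none reaches a number in this assay. On that footing the expected step of a number no higher from compound 3 to compound 4 (the limit leaves the size open) from compound 3 to compound 4 is none beyond the scatter, and compound 4 is estimated to show 100000 nM in this assay, within 30000 nM to 300000 nM, most likely again as a limit.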

Compound 4, half-maximal inhibitory concentration: > 100000 nM
Compound 4: no number, only a limit; the forecaster's own chance of this, stated with the estimate: 80%; the middle value sits exactly at the limit.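

Compound 4 yields only a limit, not a number, in this assay, so its steps from compound 1, compound 2 and compound 3 cannot be read, as both ends of each step sit at the same limit: the limit of > 100000 nM in this assay, at which 4 of the 4 values shown sit. The compounds shown leave open whether the groups on the amide-type nitrogen differ from one another at all in this assay.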